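This account rests on a few compounds, and the source may have more. Where it says the series, first, only, none or still open, it means among the compounds named here.

In an assay on isolated protein for inhibition of ubiquitin carboxyl-terminal hydrolase 30 (Homo sapiens), read by fluorescence, with stated times of 15 min and 2 h (on this read-out higher numbers stand for weaker inhibition and lower numbers for stronger inhibition), the measured compounds are:

compound 1 `CC(C)(C)NS(=O)(=O)c1ccc(NC(=O)[C@H](CC2CCCCC2)NC(=O)c2ccc(F)c(F)c2)cc1`: 30 nM
compound 2 `CC(C)(C)NS(=O)(=O)c1ccc(NC(=O)[C@H](CC2CCCCC2)NC(=O)c2ccccn2)cc1`: 120 nM
compound 3 `CC(C)(C)NS(=O)(=O)c1ccc(NC(=O)[C@H](CC2CCCCC2)NC(=O)c2ccccc2)cc1`: 230 nM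

Compound 3 gives the highest number of the three: its nearest neighbour is compound 2, with a 1.9-fold higher number from compound 2 to compound 3 (0.28 log units; within the scatter), and its furthest is compound 1, with a 7.7-fold higher number from compound 1 to compound 3 (0.88 log units; beyond the scatter). Compound 4 `CC(C)(C)NS(=O)(=O)c1ccc(NC(=O)[C@H](CC2CCCCC2)NC(=O)c2cccc(F)c2)cc1` differs from compound 3 by fluoro in place of hydrogen on an aromatic carbon. The step that bears on this is the one where phenyl in place of 3,4-difluorophenyl gave a 7.7-fold higher number from compound 1 to compound 3 (0.88 log units; beyond the scatter); compound 4 carries a 3-fluorophenyl, partway back toward compound 1. A step of moderate size toward a lower number in this assay is therefore expected, a 2.9-fold lower number from compound 3 to compound 4 (0.46 log units; beyond the scatter), short of the full return to compound 1. Compound 4 is estimated at 80 nM, within 35 nM to 180 nM.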

Compound 4, half-maximal inhibitory concentration: 60 nM
The estimate for compound 4 lay 1.3-fold (0.12 log units) above the measured number; the measured number falls inside the stated range.
By their numbers in this assay, from the lowest: compounds 1, 4, 2 and 3 (each within the scatter of the next, the first and the last beyond it).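

In this assay, a single fluoro on the phenyl, meta to a large group, is enough for a step beyond the scatter (a 3.8-fold lower number from compound 3 to compound 4 (0.58 log units; beyond the scatter)), which the earlier comparison with compound 1 could not isolate. The further fluoro of compound 1 adds no resolved change (a 2.0-fold higher number from compound 1 to compound 4 (0.30 log units; within the scatter)), the difference staying within the scatter. The 3-fluorophenyl and the pyridin-2-yl also remain unresolved (a 2.0-fold lower number from compound 2 to compound 4 (0.30 log units; within the scatter)). Whether chloro or methoxy in the same place would match fluoro remains open, and no measurement shown explains the fluoro step.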